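The compounds below may be only part of what the source reports. "The series", "measured", "known", "first", "only" and "open" are said of these compounds alone.

Working notes on the series in a functional assay on A549 cells (Homo sapiens) for cytotoxicity, read by MTT assay, with a stated time of 24 h; on this read-out higher numbers stand for weaker inhibition and lower numbers for stronger inhibition. Compound 1 `COc1cc(/C=C(\C#N)C(=O)N/N=C(\C)c2c(O)c3ccc(O)cc3oc2=O)ccc1O` gives 12600 nM. Compound 2 `COc1ccc(/C=C(\C#N)C(=O)N/N=C(\C)c2c(O)c3ccc(O)cc3oc2=O)cc1OC` gives 14300 nM, and compound 3 `C/C(=N\NC(=O)/C(C#N)=C/c1ccc(Br)cc1)c1c(O)c2ccc(O)cc2oc1=O` gives 11400 nM. Compound 1 holds the second highest of these three numbers. The nearest step is a 1.1-fold lower number from compound 1 to compound 3 (0.04 log units; within the scatter) and the furthest is a 1.1-fold higher number from compound 1 to compound 2 (0.05 log units; within the scatter); all three values sit within the scatter of one another, so no order among them can be read.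

Compound 4 `C/C(=N\NC(=O)/C(C#N)=C/c1cccc(Br)c1)c1c(O)c2ccc(O)cc2oc1=O` has not yet been measured in this assay. It differs from compound 1 in one place: 3-bromophenyl in place of 4-hydroxy-3-methoxyphenyl on a double-bonded chain carbon bound to a double-bonded chain carbon. Within the data shown here, the steps that bear on this are the two that also exchange a methoxy-bearing phenyl for a bromophenyl, a 1.1-fold lower number from compound 1 to compound 3 (0.04 log units; within the scatter) and a 1.3-fold lower number from compound 2 to compound 3 (0.10 log units; within the scatter), both within the scatter. Among the measured compounds shown here, compound 3 carries a 4-bromophenyl where compound 4 carries a 3-bromophenyl, and no measured pair compares those two groups with each other; that part of the change is unsupported by data. On what is known, no step beyond the scatter is expected for compound 4 in this assay in either direction, and a 1.1-fold lower number from compound 1 to compound 4 (0.02 log units; within the scatter) is the estimated change. Compound 4 is therefore estimated at 12000 nM, within a range of 6000 nM to 24000 nM.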

Compound 4, half-maximal inhibitory concentration: 22200 nM
The estimate for compound 4 lay 1.9-fold (0.27 log units) below the measured number, and the stated range covers the measured number.
By their numbers in this assay, from the lowest: compounds 3, 1, 2 and 4 (each within the scatter of the next).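

Among these compounds, the new compound gives the first direct comparison of the two bromophenyl groups on the double-bonded chain carbon in this assay: 3-bromophenyl in place of 4-bromophenyl gives (a 1.9-fold higher number from compound 3 to compound 4 (0.29 log units; within the scatter)), so the data show no separation between these two groups. Against the oxygen-bearing groups, 3-bromophenyl in place of 4-hydroxy-3-methoxyphenyl gives (a 1.8-fold higher number from compound 1 to compound 4 (0.25 log units; within the scatter)) and 3-bromophenyl in place of 3,4-dimethoxyphenyl gives (a 1.6-fold higher number from compound 2 to compound 4 (0.19 log units; within the scatter)), so all four aryl groups shown at this place, including the 3-bromophenyl with 0 hydrogen-bond donors and 0 hydrogen-bond acceptors, remain within the scatter of one another. No measurement at hand accounts for the size of these steps.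

As far as these compounds go, it remains open whether any group at this place can give a step beyond the scatter, for example an aryl ring carrying an amine or a carboxylic acid, or a longer chain in place of the aryl ring. The compounds shown also share the nitrile and the rest of the core, so they leave open how replacing the nitrile with a carboxylic acid, or changing the core, would read in this assay.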